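The source may report more compounds than this note shows. Statements on the series, on what has been measured and on what is new or still open speak of the compounds shown alone.

Compound 1 `O=C(Nc1ncc(C(Oc2ccc3cc(Br)ccc3c2)c2ccc(Cl)cc2)s1)c1cccs1`: in an ADME assay on HepG2 2.2.15 cells (Homo sapiens) for cytotoxicity (on this read-out lower numbers stand for higher toxicity in this test and higher numbers for lower toxicity in this test), compound 1 gives "not toxic" (no number reported).
Compound 2 `CCCCC(CC)CNc1ncc(C(Oc2ccc3cc(Br)ccc3c2)c2ccc(Cl)cc2)s1`: in this assay compound 2 gives "not toxic" (no number reported).
Compound 3 `COc1ccc(C(=O)Nc2ncc(C(Oc3ccc4cc(Br)ccc4c3)c3ccc(Cl)cc3)s2)cc1`: in this assay compound 3 gives > 50000 nM, which is a limit of the assay and not a number.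

The three measured compounds share a core, and all three read as non-toxic. Compound 3 is the only one with a reported figure, and that figure is the limit of > 50000 nM in this assay, at which 1 of the 3 values shown sits, so where compound 3 stands among its companions cannot be put into an order. For compound 1 and compound 2 no number is given at all.

Compound 4 `O=C(Nc1ncc(C(Oc2ccc3cc(Br)ccc3c2)c2ccc(Cl)cc2)s1)c1cc(F)c(F)cc1F` has not yet been measured in this assay. It differs from compound 3 in one place: 2,4,5-trifluorophenyl in place of 4-methoxyphenyl on a carbonyl carbon. Among the measured compounds shown here, no step between two measured compounds is available to calibrate this change, so what can be said rests on the limit for compound 3 alone.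

Compound 4 is expected to stay at the same limit, with a step of a number no higher from compound 3 to compound 4 (the limit leaves the size open) that is not beyond the scatter. The estimate for compound 4 is 50000 nM, within a range from 20000 nM to 100000 nM, and most likely the assay will again report only a limit for compound 4.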

Compound 4, half-maximal cytotoxic concentration: "not toxic" (no number reported)
Compound 4 has no reported number here, so the estimate cannot be set against anything.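

In this assay, among the compounds shown here, compound 4 gives "not toxic" (no number reported), so no step from compound 3 to compound 4 can be read. Compound 3 gives > 50000 nM, which is a limit and not a number. The compounds shown leave open whether replacing 4-methoxyphenyl with 2,4,5-trifluorophenyl on the carbonyl carbon changes the half-maximal cytotoxic concentration at all.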